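The source may hold more compounds than are shown below. What is called first, only, known or untested is meant among the compounds shown, and "the series" means these compounds.

Going by the values given here, compound 2 `c1cn2cc(-c3ccc4c(c3)ncn4C3CCCCC3)nc(-c3ccc4ncn(C5CCCCC5)c4c3)c2n1` stands highest of the two compounds measured so far. In a functional assay on SNB-19 cells (Homo sapiens) for inhibition, read by sulforhodamine B assay, with a stated time of 48 h, tested at 10 uM (on this read-out lower numbers stand for less inhibition and higher numbers for more inhibition at the one concentration tested (going by the name of the read-out)), compound 2 gives 10.6%. Its nearest neighbour on the numbers is compound 1 `c1cn2cc(-c3ccsc3)nc(-c3ccc4ncn(C5CCCCC5)c4c3)c2n1`; in this assay compound 1 gives 0.39%, and that gap lies beyond the usual scatter, so compound 2 does hold the higher value of the pair. Among the compounds with values here, no single-point step between the two measured compounds has been worked out, so of them only their two values can be said.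

Compound 3 `c1ccc(Cn2cnc3ccc(-c4nc(-c5ccc6c(c5)ncn6C5CCCCC5)cn5ccnc45)cc32)cc1` has not yet been measured in this assay. It differs from compound 2 at one place: benzyl in place of cyclohexyl on an aromatic nitrogen. Within the data shown here, both measured values in this assay are low, and there is no measured step of this kind to lean on, so the step is expected to be small, within the scatter and in no firm direction; the expected step is a number 1.4 percentage points higher from compound 2 to compound 3 (within the scatter). Compound 3 is therefore estimated to give about 12% in this assay, with a range from 0% to 30%.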

Compound 3, a percentage reported as inhibition, at one concentration (the size of the read-out at that concentration, not a potency): 80.4%
Compound 3: middle estimate off by 68.4 percentage points, on the low side; measured number above the stated range.
By their numbers in this assay, from the lowest: compound 1; then compound 2; then compound 3.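

In this assay, going by these compounds alone, the group on this aromatic nitrogen proves to matter a great deal: benzyl in place of cyclohexyl gives a number 69.8 percentage points higher from compound 2 to compound 3 (beyond the scatter), the first step here that can be read from a single change. A change from a six-membered non-aromatic ring of carbon only to benzyl is therefore enough to separate a compound with little inhibition at the one concentration tested from one with a high value. No measurement bears on why the step is so large, so the result stands as an observation without an explanation.

The compounds shown leave open whether the rise belongs to the aromatic ring or to the added carbon that links it to the nitrogen, a question that cyclohexylmethyl or phenyl at the same place would address. They also leave open whether the same change would give a higher number where compound 3 still carries its other cyclohexyl, and whether the number would be higher, lower or level with a further group such as an amine or a carboxylic acid on the benzyl ring.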